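A few compounds are considered here, and "the series" means these few. Any claim that something is new, unique, unknown or untested is made for them only; others in the source may bear on it.

Series of thiocarbamates on a shared core. Compound 1 `S=C(Nc1ccccc1)OCCc1ccccn1` is the reference point. In an ADME assay on MT4 cells (Homo sapiens) for cytotoxicity, read by MTT assay (on this read-out higher numbers stand for lower toxicity in this test and lower numbers for higher toxicity in this test), compound 1 gives > 100000 nM, which is a limit of the assay and not a number. Compound 2 `S=C(Nc1ccccc1Cl)OCCc1ccccn1` carries chloro in place of hydrogen on an aromatic carbon. In this assay compound 2 gives > 100000 nM, again a limit rather than a number. For the measured compounds named here, the only measured step, a step that the two limits leave unreadable from compound 1 to compound 2, is therefore not readable in size; both values sit at the limit of > 100000 nM in this assay, at which 2 of the 2 values shown sit, so no measured change on this read-out is available.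

Compound 3 `FC(F)(F)c1ccc(NC(=S)OCCc2ccccn2)cc1` is the next case, differing from compound 1 by trifluoromethyl in place of hydrogen on an aromatic carbon. Going by the values given here, the one measured step, from compound 1 to compound 2, bears on it only in kind, as another substituent entering the same aromatic ring, and gives no size to carry over. The step from compound 1 to compound 3 in this assay is expected to be a step that the limit leaves unreadable from compound 1 to compound 3, most probably with the value again reported only as a limit. Compound 3 is estimated at 150000 nM, within the range 50000 nM to 400000 nM.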

Compound 3, half-maximal cytotoxic concentration: 50000 nM
Compound 3: the middle estimate sits 3.0-fold (0.48 log units) above what was measured, and the stated range covers the measured number.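

Trifluoromethyl on an aromatic carbon, para to a large group, brings the first read-out in this assay that is a number and not a limit: compound 3 gives 50000 nM. The change is an at least 2.0-fold lower number from compound 1 to compound 3 (0.30 log units; that floor lies within the scatter); since only a floor can be stated, the direction on this read-out points towards higher toxicity in this test, but the printed minimum does not by itself establish a change beyond the usual scatter. This substitution therefore gives the series its only measured point, while the other values remain at the upper limit of the test: the limit of > 100000 nM in this assay, at which 2 of the 3 values shown sit.

As far as these compounds go, the true size of the step stays open, as the number for compound 1 lies somewhere beyond its limit, and a single substitution cannot show whether the result follows from trifluoromethyl itself or from its place on the ring. An amine, a carboxylic acid or a methoxy group on the same aromatic carbon would show whether other groups at this place also bring the read-out down from the limit.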